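The source may hold more compounds than are shown below. What is called first, only, known or untested is meant among the compounds shown, and "the series" means these compounds.

Measured so far:
compound 1 `CC(C)c1c(C(=O)NCc2ccccc2)nc(-c2ccc(F)cc2)n1CC[C@@H](O)C[C@@H](O)CC(=O)O` gives 0.3 nM in a functional assay on cells (Hepatocyte, Rattus norvegicus) for inhibition, read by scintillation counting, with a stated time of 4 h; on this read-out lower numbers stand for stronger inhibition and higher numbers for weaker inhibition
compound 2 `Cc1ccc(CNC(=O)c2nn(-c3ccc(F)cc3)c(CC[C@@H](O)C[C@@H](O)CC(=O)O)c2C(C)C)cc1` gives 0.9 nM in this assay
compound 3 `COc1cccc(CNC(=O)c2nc(-c3ccc(F)cc3)n(CC[C@@H](O)C[C@@H](O)CC(=O)O)c2C2CC2)c1` gives 0.2 nM in this assay

Of the three numbers, that of compound 3 is the lowest. Compound 1 is its nearest neighbour, and the gap between them lies within the scatter, so nothing separates the two. Compound 2 stands furthest away, and that gap lies beyond the scatter.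

Compound 4 `O=C(O)C[C@H](O)C[C@H](O)CCn1c(-c2ccc(F)cc2)nc(C(=O)NCc2ccccc2)c1C1CC1` differs from compound 3 in one place: hydrogen in place of methoxy on an aromatic carbon. Among the compounds with values here, no single-point step between two measured compounds is available to anchor this change; compound 1 also carries a plain benzyl group, but it differs from compound 3 elsewhere as well, so the pair only shows that both give very low numbers in this assay. On that basis a step of no size beyond the scatter is expected, perhaps a slightly higher number, as a 1.5-fold higher number from compound 3 to compound 4 (0.18 log units; within the scatter). Compound 4 is therefore estimated at 0.3 nM in this assay, with a range of 0.1 nM to 1 nM.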

Compound 4, half-maximal inhibitory concentration: 0.2 nM
The estimate for compound 4 lay 1.5-fold (0.18 log units) above the measured number; low and high end bracket the measured number.
By their numbers in this assay, from the lowest: compounds 3, 4 and 1 (each within the scatter of the next); then compound 2.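

In this assay, hydrogen in place of methoxy gives no change at the digits printed from compound 3 to compound 4 (within the scatter), so on this core the 3-methoxybenzyl and benzyl groups cannot be told apart by their numbers. Within the data shown here, compound 4 also provides the first single-place comparison with compound 1: cyclopropyl in place of isopropyl on an aromatic carbon gives a 1.5-fold lower number from compound 1 to compound 4 (0.18 log units; within the scatter), so these two groups cannot be told apart here either. No evidence is at hand to explain either result.

The compounds shown leave open whether another group at the methoxy position, such as an amine or a carboxylic acid, would move the number beyond the scatter. On these data alone, whether hydrogen in place of methoxy would be just as silent on the core of compound 2 also remains open.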